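Acid Chain Change on a Shared Core: Expected Solubility

The source may report more compounds than this note shows. Statements on the series, on what has been measured and on what is new or still open speak of the compounds shown alone.

Measured so far:
Compound 1 `CC(C)(Oc1ccc([C@H]2CC[C@]3(CC2)OOC2(O3)C3CC4CC(C3)CC2C4)cc1)C(=O)O` gives < 1.6 ug/mL
Compound 2 `O=C(O)COc1ccc([C@H]2CC[C@]3(CC2)OOC2(O3)C3CC4CC2CC(C3)C4(F)F)cc1` gives < 1.6 ug/mL

Of the compounds shown here, two have been measured in a physicochemical assay for solubility, read by nephelometry, in phosphate buffer, measured as kinetic solubility, with a stated time of 30 min, at pH 6.5; a lower number here means a less soluble compound, a higher number a more soluble compound. For compound 1 the value < 1.6 ug/mL is a limit of the assay and not a number. For compound 2 the value < 1.6 ug/mL is likewise a limit. Compound 1 therefore stands at the limit of < 1.6 ug/mL in this assay, at which 2 of the 2 values shown sit, and the same is true of compound 2, so the numbers shown do not set either compound apart from the other.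

Compound 3 `O=C(O)CCCCOc1ccc([C@H]2CC[C@]3(CC2)OOC2(O3)C3CC4CC(C3)CC2C4)cc1` has not yet been measured in this assay. It differs from compound 1 in one place: 4-carboxybutyl in place of 1-carboxy-1-methylethyl on an oxygen on an aromatic ring. Among the measured compounds shown here, no measured pair shows a change of this kind, so nothing among the known values tells how large a step to expect.

Compound 3 is expected to remain close to where compound 1 sits, with the step that the limit leaves unreadable from compound 1 to compound 3 expected to lie within the usual scatter rather than beyond it. Compound 3 is estimated at 1.2 ug/mL, with a range from 0.4 ug/mL to 3.5 ug/mL.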

Compound 3, solubility: < 1.6 ug/mL
Compound 3 gave a limit, no number; the forecaster's own chance of this, stated with the estimate: 75%; the middle value does not contradict the limit.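

In this assay compound 3 gives a limit and not a number, as compound 1 does, so no step between compound 1 and compound 3 can be read: the limit of < 1.6 ug/mL in this assay, at which 3 of the 3 values shown sit.

The compounds shown leave open where each one truly lies under that limit, and whether 4-carboxybutyl in place of 1-carboxy-1-methylethyl changes the reading at all.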